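The source may report more compounds than this note shows. Statements on the series, on what has been measured and on what is new or still open speak of the compounds shown alone.

Working notes on the series, read in a functional assay on PANC-1 cells (Homo sapiens) for inhibition, read by XTT assay, with a stated time of 72 h; a lower number here means a stronger inhibitor, a higher number a weaker inhibitor. Compound 1 `C=CCCCCCCCCCOC[C@@H]1CCCN1[S+]([O-])c1ccc(C)cc1` gives 56700 nM. Compound 2 `CCCCCCCC/C=C\CCCCCCCCOC[C@@H]1CCCN1[S+]([O-])c1ccc(C)cc1` stands at > 100000 nM, which is a limit of the assay and not a number. For the measured compounds named here, the one measured step is an at least 1.7-fold higher number from compound 1 to compound 2 (0.24 log units; that floor lies within the scatter), and it changes only the chain. Compound 3 `CCCCCCCC/C=C\CCCCCCCCOC[C@@H]1CCCN1C(=O)CN` keeps the chain of compound 2, and the change is on the amine nitrogen in the ring: a group of 4 heavy atoms (2 carbon, 1 nitrogen, 1 oxygen; no ring) in place of a group of 9 heavy atoms (7 carbon, 1 oxygen, 1 sulfur; one six-membered aromatic ring of carbon only), on an amine nitrogen in a ring. (Aminomethyl)carbonyl is the group that enters. Going by the values given here, no measured step touches this place, so the series gives no size to carry over. A moderate move toward a lower number in this assay is expected, with a reading at the limit still possible. The expected step is an at least 3.3-fold lower number from compound 2 to compound 3 (0.52 log units; beyond the scatter). For compound 3 the estimate is 30000 nM, with an expected range from 8000 nM to 100000 nM.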

Compound 3, half-maximal inhibitory concentration: 7700 nM
Compound 3: middle estimate off by 3.9-fold (0.59 log units), on the high side; measured number below the stated range.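

With the chain held constant, (aminomethyl)carbonyl on the amine nitrogen in the ring gives an at least 12-fold lower number from compound 2 to compound 3 (1.11 log units; beyond the scatter) in this assay. For the compounds shown here, this is the first step at this place, and it lies beyond the scatter, whereas the floor of the earlier chain step did not. Its printed size is only a floor because compound 2 stands at a limit of the assay and not at a number: the limit of > 100000 nM in this assay, at which 1 of the 3 values shown sits.

The compounds shown do not separate the contribution of the amine from that of the carbonyl in the entering group; acetyl on the same nitrogen would bear on that. Also open, from the compounds shown here alone, is whether (aminomethyl)carbonyl gives a similar step on the undecenyl-type chain of compound 1, or whether a longer aminoalkyl carbonyl group would read differently.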